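The compounds below may be only part of what the source reports. "The series", "measured", "known", "first", "only" and "open" are said of these compounds alone.

In a functional assay on RAW264.7 cells (Mus musculus) for inhibition, read by Griess assay, with stated times of 1 h and 24 h (a higher number here means a weaker inhibitor, a lower number a stronger inhibitor), compound 1 `O=C1CC(c2ccccc2OCc2ccccc2)Oc2ccccc21` gives 18900 nM, the lowest of the three numbers measured. Compound 2 `CC(C)=CCOc1ccccc1C1CC(=O)c2ccccc2O1` gives 32700 nM and compound 3 `CCCOc1ccccc1C1CC(=O)c2ccccc2O1` gives 46000 nM. Compound 4 `CC(C)CCOc1ccccc1C1CC(=O)c2ccccc2O1` has not yet been measured; it differs from compound 1 in one place: isobutyl in place of phenyl on a saturated chain carbon bound to an oxygen on an aromatic ring. Among the compounds with values here, two measured steps bear on this change, each also removing phenyl on a saturated chain carbon bound to an oxygen on an aromatic ring: a 1.7-fold higher number from compound 1 to compound 2 (0.24 log units; within the scatter) and a 2.4-fold higher number from compound 1 to compound 3 (0.39 log units; beyond the scatter). Both moved the number upward, one within the scatter and the other modestly beyond it. A similar modest rise is therefore expected for compound 4, a 1.9-fold higher number from compound 1 to compound 4 (0.27 log units; within the scatter). In this assay compound 4 is expected to give about 35000 nM, with a likely range from 18000 nM to 70000 nM.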

Compound 4, half-maximal inhibitory concentration: 39200 nM
Estimate against measurement, compound 4: 1.1-fold (0.05 log units) below; the range from low to high includes it.
By their numbers in this assay, from the lowest: compounds 1, 2, 4 and 3 (each within the scatter of the next, the first and the last beyond it).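

In this assay, isobutyl in place of phenyl gives a 2.1-fold higher number from compound 1 to compound 4 (0.32 log units; beyond the scatter), so this saturated chain joins the ethyl of compound 3 in a step beyond the scatter, whereas the step to the 2-methylprop-1-en-1-yl of compound 2 stayed within it. The other two steps, a 1.2-fold lower number from compound 3 to compound 4 (0.07 log units; within the scatter) and a 1.2-fold higher number from compound 2 to compound 4 (0.08 log units; within the scatter), lie within the scatter, so the three groups without phenyl are not told apart. Nothing available explains why phenyl differs from these chains. As far as these compounds go, whether a cyclohexyl group, a substituted phenyl or a chain ending in an amine would match or pass phenyl remains open.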